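A few compounds are considered here, and "the series" means these few. Any claim that something is new, unique, unknown or untested is made for them only; others in the source may bear on it.

Compound 1 `N#Cc1cc(NCc2ccccc2[N+](=O)[O-])c2cn[nH]c2c1` stands at the edge of what an assay for inhibition of Tryptophan 2,3-dioxygenase (Homo sapiens), with stated times of 10 min and 60 min (a higher number here means a weaker inhibitor, a lower number a stronger inhibitor), can report: in this assay compound 1 gives > 100000 nM, a limit rather than a number (the limit of > 100000 nM in this assay, at which 1 of the 2 values shown sits). Compound 2 `O=[N+]([O-])c1cc(Br)c(F)cc1CNc1cc(C(F)(F)F)cc2[nH]ncc12`, which shares the core, gives 1460 nM in this assay. Compound 3 `O=[N+]([O-])c1ccccc1CNc1cc(C(F)(F)F)cc2[nH]ncc12` differs from compound 1 by trifluoromethyl in place of cyano on an aromatic carbon. Among the compounds with values here, no measured step covers this change alone, so its size is unknown; a move toward stronger inhibition is expected, amounting to an at least 8.3-fold lower number from compound 1 to compound 3 (0.92 log units; beyond the scatter). Compound 3 is therefore estimated at 12000 nM, with a range from 2500 nM to 60000 nM.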

Compound 3, half-maximal inhibitory concentration: 2550 nM
Compound 3: the middle estimate sits 4.7-fold (0.67 log units) above what was measured; the measured number falls inside the stated range.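

Within the data shown here, at this aromatic carbon, trifluoromethyl in place of cyano gives the first measured step: in this assay the change yields an at least 39-fold lower number from compound 1 to compound 3 (1.59 log units; beyond the scatter). The change therefore moves the shared core from an unquantified reading to a measurable one. Compound 1 is recorded only as a limit, so the true size of the step remains open: the limit of > 100000 nM in this assay, at which 1 of the 3 values shown sits.

As far as these compounds go, whether a methyl, an amine or a carboxylic acid at this carbon would read like trifluoromethyl or like cyano remains open. So does whether this step holds when the other aromatic ring carries different groups.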